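Swapping Methoxy for Trifluoromethyl on the Carbamate Ring

The source may report more compounds than this note shows. Statements on the series, on what has been measured and on what is new or still open speak of the compounds shown alone.

Compound 1 `CCOc1cc(=O)n(CCCO)c2c1CC(C/C=C(\C)CCC=C(C)C)C(C)(C)C2` gives 67.8% in a functional assay on PANC-1 cells (Homo sapiens) for inhibition, read by MTT assay, with a stated time of 24 h, tested at 10 uM; a higher number here means more inhibition at the concentration tested (going by the name of the read-out), a lower number less inhibition. Compound 2 `COc1cccc(NC(=O)Oc2cc(=O)n(CCCO)c3c2CC(C/C=C(\C)CCC=C(C)C)C(C)(C)C3)c1` gives 47% in this assay, the lower of the two numbers, set apart from compound 1 by a number 20.8 percentage points lower from compound 1 to compound 2 (beyond the scatter). Compound 3 `CC(C)=CCC/C(C)=C/CC1Cc2c(OC(=O)Nc3cccc(C(F)(F)F)c3)cc(=O)n(CCCO)c2CC1(C)C` differs from compound 2 by trifluoromethyl in place of methoxy on an aromatic carbon. Among the compounds with values here, no measured step exchanges one group for another on that outer ring, so the one measured step gives no guide to size or direction here, and the expected change is none beyond the scatter: no change at the digits printed from compound 2 to compound 3 (within the scatter). Compound 3 is therefore estimated at 47%, within a range from 30% to 65%.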

Compound 3, a percentage reported as inhibition, at one concentration (the size of the read-out at that concentration, not a potency): 44%
For compound 3 the middle estimate is 3 percentage points above the measured one, and the stated range covers the measured number.
By their numbers in this assay, from the lowest: compounds 3 and 2 (each within the scatter of the next); then compound 1.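

Within the data shown here, exchanging methoxy for trifluoromethyl on the outer ring gives a number 3 percentage points lower from compound 2 to compound 3 (within the scatter) in this assay, the first measured exchange at this place on the ring. The two groups share no atom type beyond carbon, yet their numbers here cannot be told apart, so this one pair gives no sign that the group at this position matters. No measurement on hand accounts for this result. Still open, as far as these compounds go, is whether an amine or a carboxylic acid at this place would give a number beyond the scatter, and whether methoxy or trifluoromethyl would behave alike elsewhere on the ring.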